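The source may report more compounds than this note shows. Statements on the series, on what has been measured and on what is new or still open speak of the compounds shown alone.

Three amides on the shared core have been read in a functional assay on SW 1116 cells (Homo sapiens) for antiproliferative activity, read by MTT assay, with a stated time of 48 h; a higher number here means that more compound is needed for the effect, a lower number that less compound is needed. Compound 1 `Cc1ccccc1C(=O)Nc1nnc(-c2ccc3c(c2)OCCO3)s1` gives > 100 ug/mL, which is a limit of the assay and not a number. Compound 2 `O=C(CCc1ccccc1)Nc1nnc(-c2ccc3c(c2)OCCO3)s1` gives 16.2 ug/mL. Compound 3 `Nc1ccc(C(=O)Nc2nnc(-c3ccc4c(c3)OCCO4)s2)cc1` gives 41.2 ug/mL, the higher of the two actual numbers. Between these two lies a 2.5-fold higher number from compound 2 to compound 3 (0.41 log units; beyond the scatter).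

Compound 4 `O=C(Nc1nnc(-c2ccc3c(c2)OCCO3)s1)c1ccc(Cl)nc1` carries 6-chloropyridin-3-yl in place of 4-aminophenyl on a carbonyl carbon. Within the data shown here, no measured step makes this exact exchange. The closest is an at least 2.4-fold lower number from compound 1 to compound 3 (0.38 log units; beyond the scatter), where 4-aminophenyl replaces 2-methylphenyl, so exchanging one six-membered aromatic ring for another at this place has already shifted the number beyond the scatter. The other measured step, an at least 6.1-fold lower number from compound 1 to compound 2 (0.79 log units; beyond the scatter), replaces 2-methylphenyl with phenethyl. Both compounds with an aromatic ring named on the carbonyl carbon read higher than the phenethyl amide, and compound 4 joins that group.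

These steps do not fix a direction for the new exchange, so no step beyond the scatter is expected in this assay, with a slight lean towards a higher number. The expected change is a 1.3-fold higher number from compound 3 to compound 4 (0.13 log units; within the scatter). As far as these compounds go, the upper end stays open, and the limit of > 100 ug/mL in this assay, at which 1 of the 3 values shown sits, may apply here too. For compound 4 the estimate is 55 ug/mL, with an expected range of 20 ug/mL to 130 ug/mL.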

Compound 4, half-maximal effective concentration: 30.4 ug/mL
For compound 4 the middle estimate is 1.8-fold (0.26 log units) above the measured one; the range from low to high includes it.
By their numbers in this assay, from the lowest: compounds 2, 4 and 3 (each within the scatter of the next, the first and the last beyond it). At a limit, above all of these: compound 1.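

The exchange of 4-aminophenyl for 6-chloropyridin-3-yl on a carbonyl carbon gives in this assay a step of a 1.4-fold lower number from compound 3 to compound 4 (0.13 log units; within the scatter) even though the hydrogen-bond donor is lost and a hetero atom enters the ring, so neither change visibly moves the read-out at this place. The earlier separation of compound 3 from the phenethyl amide does not extend to every aromatic amide, since the new comparison shows a 1.9-fold higher number from compound 2 to compound 4 (0.27 log units; within the scatter) and compound 3 alone remains apart from compound 2. A third comparison shows an at least 3.2-fold lower number from compound 1 to compound 4 (0.51 log units; beyond the scatter) and places the 2-methylphenyl amide apart from the other three, with compound 1 alone at a limit of the assay, not a number: the limit of > 100 ug/mL in this assay, at which 1 of the 4 values shown sits.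

With the ring nitrogen and the chlorine entering together, their separate contributions cannot be told apart, and 4-chlorophenyl or unsubstituted pyridin-3-yl on the carbonyl carbon would divide them. As far as these compounds go, whether the amino group of compound 3 can be exchanged for a carboxylic acid, or the phenethyl chain of compound 2 lengthened to a 4-phenylbutyl chain, without a step beyond the scatter also stays open.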